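The source may report more compounds than this note shows. Statements on the series, on what has been measured and on what is new or still open speak of the compounds shown alone.

Notes on the series. Compound 1 `COc1ccc2nc(C)cc(NCc3cccc(F)c3)c2c1`, compound 2 `COc1ccc2nc(C)cc(NCc3ccccc3F)c2c1` and compound 3 `COc1ccc2nc(C)cc(NCc3ccc(F)cc3F)c2c1` have been measured in a functional assay on MCF-10A cells (Homo sapiens) for antiproliferative activity, with a stated time of 48 h; a higher number here means that more compound is needed for the effect, a lower number that less compound is needed. In this assay compound 1 gives 14700 nM, compound 2 gives 17000 nM, and compound 3 gives 15000 nM. The cores of compound 1 and compound 2 differ as 3-fluorophenyl in place of 2-fluorophenyl on a saturated chain carbon bound to a nitrogen on an aromatic ring; this change gave a 1.2-fold higher number from compound 1 to compound 2 (0.06 log units; within the scatter). Compound 4 `COc1ccc2nc(C)cc(NCc3cc(F)cc(F)c3)c2c1` has not yet been measured; it differs from compound 1 as fluoro in place of hydrogen on an aromatic carbon. The same kind of change, (fluoro in place of hydrogen on an aromatic carbon), occurs once among the measured compounds and gave a 1.1-fold lower number from compound 2 to compound 3 (0.05 log units; within the scatter); the places differ in that the entering fluoro is para to a large group in compound 3 but meta to a large group in compound 4. Because a 1.1-fold lower number from compound 2 to compound 3 (0.05 log units; within the scatter) stayed within the scatter, the step of a 1.1-fold lower number from compound 1 to compound 4 (0.04 log units; within the scatter) is expected to be of similar size. Compound 4 is therefore estimated at 13500 nM, with a range from 7000 nM to 27000 nM.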

Compound 4, half-maximal effective concentration: 18100 nM
For compound 4 the middle estimate is 1.3-fold (0.13 log units) below the measured one; the range from low to high includes it.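

Fluoro in place of hydrogen on an aromatic carbon gave a 1.2-fold higher number from compound 1 to compound 4 (0.09 log units; within the scatter) in this assay, and the two occurrences of this change do not differ: the same change on two cores in this assay, a 1.1-fold lower number (0.05 log units; within the scatter) from compound 2 to compound 3 and a 1.2-fold higher number (0.09 log units; within the scatter) from compound 1 to compound 4, 1.4-fold (0.14 log units) apart, within the scatter of two such steps

On these two cores, then, the change carries over without a step beyond the scatter. That shows only that it stays small in both of these places; two pairs give no rule for the series and no direction for the change.

Open, going by these compounds, is whether a different group on the same ring, such as chloro, an amine or a carboxylic acid, would move the number beyond the scatter. Also open, on these data alone, is what a longer chain between the ring and the nitrogen would do.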